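The compounds below may be only part of what the source reports. "The series", "measured", "known", "first", "only" and "open" are said of these compounds alone.

Measured so far:
- compound 1, `CC(C)(C)Cc1csc(N)c1C(=O)c1cccc(Cl)c1`: 8%
- compound 2, `CC(C)(C)Cc1c(-c2cccc(F)c2F)sc(N)c1C(=O)c1ccc(Cl)cc1`: 1%

Both compounds were tested in an assay on CHO cells for displacement of a labelled ligand from adenosine receptor A3 (Homo sapiens), read by scintillation counting, tested at 10 uM; on this read-out higher numbers stand for more inhibition at the one concentration tested (going by the name of the read-out) and lower numbers for less inhibition. Compound 1 `CC(C)(C)Cc1csc(N)c1C(=O)c1cccc(Cl)c1` gives 8% in this assay, and compound 2 `CC(C)(C)Cc1c(-c2cccc(F)c2F)sc(N)c1C(=O)c1ccc(Cl)cc1` gives 1%. Compound 2 has the lower of the two numbers, yet the gap to compound 1 lies within the usual scatter of such a measurement, so the two cannot be told apart: both show little displacement of the labelled ligand at the concentration tested.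

The next compound, compound 3 `CC(C)(C)Cc1c(-c2ccccc2)sc(N)c1C(=O)c1ccc(Cl)cc1`, has not yet been measured. It differs from compound 2 in one place: phenyl in place of 2,3-difluorophenyl on an aromatic carbon. The group that enters is a plain phenyl on the aromatic carbon of the shared core next to the ring sulfur, in place of the 2,3-difluorophenyl of compound 2.

Among the compounds with values here, since compound 1 and compound 2 both give low numbers, and no step between measured compounds shows what a change at this position does, the expectation for compound 3 is a step from compound 2 of a number 4 percentage points higher from compound 2 to compound 3 (within the scatter), that is, none beyond the scatter. Compound 3 is therefore expected to give about 5% in this assay, with a range from -5% to 20%.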

Compound 3, a percentage reported as inhibition, at one concentration (the size of the read-out at that concentration, not a potency): 1%
Compound 3: the middle estimate sits 4 percentage points above what was measured; the range from low to high includes it.
By their numbers in this assay, from the lowest: compounds 2, 3 and 1 (each within the scatter of the next).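

In this assay, within the data shown here, putting phenyl in place of 2,3-difluorophenyl on the aromatic carbon next to the ring sulfur gives no change at the digits printed from compound 2 to compound 3 (within the scatter) and provides the first direct comparison between two compounds that differ in one place. Taking away the two fluorine atoms of that ring, while keeping the ring itself, therefore makes no difference that this measurement can detect. Both compounds show little inhibition at the one concentration tested, so this step says only that neither of these two rings brings out displacement of the labelled ligand, and nothing here explains that result.

Still open, as far as these compounds go, is whether a different kind of group on this carbon, such as a carboxylic acid, a morpholine ring or a longer alkyl chain, would give a number clearly beyond the scatter. Also open, from the compounds shown here alone, is whether the two fluorine atoms would matter on a compound with a higher starting number, since a step between two low numbers cannot settle that.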